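A few compounds are considered here, and "the series" means these few. Any claim that something is new, unique, unknown or untested is made for them only; others in the source may bear on it.

Measured compounds:
- compound 1 `CC1=NC(C)=C(C(=O)O)C(c2ccc([N+](=O)[O-])cc2)/C1=C(\O)OC/C=C/c1ccccc1`: 1600 nM
- compound 2 `CC1=NC(C)=C(C(=O)O)C(c2cccc(Cl)c2)/C1=C(\O)OC/C=C/c1ccc(C)cc1`: 6.8 nM

In a functional assay on thoracic aorta for inhibition of Voltage-gated L-type calcium channel (Rattus norvegicus) (on this read-out lower numbers stand for stronger inhibition and higher numbers for weaker inhibition), compound 1 gives 1600 nM, and compound 2 gives 6.8 nM. Compound 2 holds the lowest of the two numbers; its nearest neighbour is compound 1, whose number is higher, with the gap between the two beyond the usual scatter. For the measured compounds named here, compounds 1 and 2 differ in more than one place, so no single-change step between measured compounds is at hand.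

Compound 3 `CC1=NC(C)=C(C(=O)O)C(c2cccc(Cl)c2)/C1=C(\O)OCc1ccc2ccccc2c1` is not yet measured. It differs from compound 2 in one place: naphthalen-2-yl in place of 2-(4-methylphenyl)ethenyl on a saturated chain carbon bound to an oxygen on an unsaturated carbon. The group that leaves and the group that enters are both aromatic and of comparable extent, and the shared core of compound 2 is kept. Going by the values given here, no measured step of this kind exists in the set, so the expected step of a 2.2-fold higher number from compound 2 to compound 3 (0.34 log units; beyond the scatter) is small, at most a slight rise, not clearly beyond the scatter. Compound 3 is expected to give 15 nM, within a range from 4 nM to 60 nM.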

Compound 3, half-maximal inhibitory concentration: 14 nM
For compound 3 the middle estimate is 1.1-fold (0.03 log units) above the measured one, within the range that was stated.
By their numbers in this assay, from the lowest: compound 2; then compound 3; then compound 1.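

In this assay, for the compounds shown here, this is the first single-change step, at the position on a saturated chain carbon bound to an oxygen on an unsaturated carbon: naphthalen-2-yl in place of 2-(4-methylphenyl)ethenyl gives a 2.1-fold higher number from compound 2 to compound 3 (0.31 log units; beyond the scatter) and leaves compound 3 at 14 nM. Removing the double bond outside aromatic rings and going from one to two six-membered aromatic rings therefore costs only a modest step at this place. Nothing at hand explains the size of this step.

From the compounds shown here alone, whether a non-aromatic group such as cyclohexyl or a saturated chain such as 3-phenylpropyl would be accepted at this place stays open. The gap between compound 1 and compound 2 also cannot yet be divided between the two places in which they differ.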